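Thiophen-2-yl in place of iodo on a shared core

The compounds below may be only part of what the source reports. "The series", "measured", "known", "first", "only" and "open" are said of these compounds alone.

Compound 3 `Cc1cc(I)cn2c(CSCCc3ccccc3)cnc12` stands apart in that its value is only a limit of the assay: in an ADME assay on HEL cells (Homo sapiens) for cytotoxicity, with a stated time of 3 days (a lower number here means that less compound is tolerated, a higher number that more compound is tolerated), compound 3 gives > 50 ug/mL. Compound 1 `Cc1cc(-c2ccccc2)cn2c(CSCCc3ccccc3)cnc12` gives 31 ug/mL in this assay, and compound 2 `COc1cccc(-c2cc(C)c3ncc(CSCCc4ccccc4)n3c2)c1` gives 36 ug/mL. The change to compound 4 `Cc1cc(-c2cccs2)cn2c(CSCCc3ccccc3)cnc12` is thiophen-2-yl in place of iodo on an aromatic carbon. The measured steps that bear on it run the other way, from phenyl or 3-methoxyphenyl to iodo: an at least 1.6-fold higher number from compound 1 to compound 3 (0.20 log units; that floor lies within the scatter) and an at least 1.3-fold higher number from compound 2 to compound 3 (0.14 log units; that floor lies within the scatter), both capped because of the limit described in the limit of > 50 ug/mL in this assay, at which 1 of the 3 values shown sits. Since those steps ran upward, compound 4 is expected to step back down, an at least 1.5-fold lower number from compound 3 to compound 4 (0.19 log units; that floor lies within the scatter). The estimated value for compound 4 is 32 ug/mL, with a range from 15 ug/mL to 60 ug/mL.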

Compound 4, half-maximal cytotoxic concentration: 32 ug/mL
Compound 4: the middle estimate sits on the measured number at the digits printed; low and high end bracket the measured number.
By their numbers in this assay, from the lowest: compounds 1, 4 and 2 (each within the scatter of the next). At a limit, above all of these: compound 3.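

Thiophen-2-yl at this aromatic carbon behaves like the phenyl and 3-methoxyphenyl groups in this assay, so a five-membered aromatic ring with a sulfur does not set compound 4 apart: a 1.0-fold higher number from compound 1 to compound 4 (0.01 log units; within the scatter), and a 1.1-fold lower number from compound 2 to compound 4 (0.05 log units; within the scatter). The change from iodo gives an at least 1.5-fold lower number from compound 3 to compound 4 (0.19 log units; that floor lies within the scatter). That step rests on a limit for compound 3, so its full size stays unknown: the limit of > 50 ug/mL in this assay, at which 1 of the 4 values shown sits.

The compounds shown leave open whether a non-aromatic group at this carbon, such as an amine or a carboxylic acid, would depart from the values of the three aryl compounds.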